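Fluoro in place of chloro on an aromatic carbon

A few compounds are considered here, and "the series" means these few. Any claim that something is new, unique, unknown or untested is made for them only; others in the source may bear on it.

Measured so far:
compound 1 `COc1cc2c(Nc3ccc(NC(=O)Nc4cccc(F)c4)c(F)c3)ncnc2cc1OCC1CCN(C)CC1`: 185 nM
compound 2 `CN1CCC(COc2ccc3c(Nc4ccc(NC(=O)Nc5cccc(F)c5)c(Cl)c4)ncnc3c2)CC1`: 132 nM

In a functional assay on HUVEC cells (Homo sapiens) for antiproliferative activity, read by sulforhodamine B assay, with a stated time of 48 h (on this read-out higher numbers stand for weaker inhibition and lower numbers for stronger inhibition), compound 2 gives 132 nM and compound 1 gives 185 nM. These two numbers lie within the scatter of each other, so no order can be read between them.

The next compound is compound 3 `CN1CCC(COc2ccc3c(Nc4ccc(NC(=O)Nc5cccc(F)c5)c(F)c4)ncnc3c2)CC1`. Relative to compound 2, it carries fluoro in place of chloro on an aromatic carbon, ortho to a ((3-fluorophenyl)carbamoyl)amino group and meta to a large group: fluoro in place of chloro on an aromatic carbon.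

Among the measured compounds shown here, no pair of measured compounds differs in only one place, so the data give no direct measure of this exchange. With so little to go on, no step beyond the scatter is expected in this assay, in either direction.

For compound 3 the expected value is 150 nM, with an estimated range of 70 nM to 320 nM. The expected change is a 1.1-fold higher number from compound 2 to compound 3 (0.06 log units; within the scatter), which would stay within the scatter.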

Compound 3, half-maximal inhibitory concentration: 67 nM
For compound 3 the middle estimate is 2.2-fold (0.35 log units) above the measured one; measured number below the stated range.
By their numbers in this assay, from the lowest: compounds 3, 2 and 1 (each within the scatter of the next, the first and the last beyond it).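

In this assay, the exchange of chloro for fluoro on the aromatic carbon ortho to the ((3-fluorophenyl)carbamoyl)amino group gives a 2.0-fold lower number from compound 2 to compound 3 (0.29 log units; within the scatter), so no order can be read between these two halogens at this position, and either one is compatible with activity in the same range. Among the compounds shown here, the first direct reading on the methoxy group comes from hydrogen in place of methoxy on an aromatic carbon, which gives a 2.8-fold lower number from compound 1 to compound 3 (0.44 log units; beyond the scatter), so in this pair the methoxy group is not needed for activity, and its removal brings a modest step towards stronger inhibition. No measurement bearing on the origin of either step is available.

As far as these compounds go, whether this tolerance extends to other groups at the position ortho to the ((3-fluorophenyl)carbamoyl)amino group, such as bromo, methyl or a nitrile, or to hydrogen there, remains open. Also open, from the compounds shown here alone, is whether the methoxy step holds with chloro in place of fluoro, and whether a larger ether such as ethoxy at the methoxy position behaves like methoxy or departs further from hydrogen.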